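From cyclohexyl to 4-fluorophenyl on a carbonyl carbon

The source may report more compounds than this note shows. Statements on the series, on what has been measured and on what is new or still open speak of the compounds shown alone.

In an ADME assay on cells (Hepatocyte, Mus musculus) for metabolic stability, with a stated time of 30 min (a lower number here means that less of the compound is left, a higher number that more of the compound is left), compound 2 `O=C(OC1CCC(CN2CCN(c3cc(=O)c4cc(C(F)(F)F)cc([N+](=O)[O-])c4s3)CC2)CC1)C1CCCCC1` gives 1.2%. Within the data shown here, the only other measured compound, compound 1 `O=C(OC1CCC(CN2CCN(c3cc(=O)c4cc(C(F)(F)F)cc([N+](=O)[O-])c4s3)CC2)CC1)c1ccncc1`, gives 1.4%, so the two stand within the scatter of each other, and very little of either is left at the end of the incubation. Compound 3 `O=C(OC1CCC(CN2CCN(c3cc(=O)c4cc(C(F)(F)F)cc([N+](=O)[O-])c4s3)CC2)CC1)c1ccc(F)cc1` has not yet been measured. It differs from compound 2 at the same carbonyl carbon: 4-fluorophenyl in place of cyclohexyl on a carbonyl carbon. In short, 4-fluorophenyl stands in place of cyclohexyl.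

Among the measured compounds shown here, one measured step bears on this change. Cyclohexyl in place of pyridin-4-yl at this carbonyl carbon gave a number 0.2 percentage points lower from compound 1 to compound 2 (within the scatter). For the measured compounds named here, that step is small, but it is the only evidence available, and no measured compound carries fluorine at this place. Going by the values given here, a large rise cannot be excluded, although nothing measured so far points to one. The step expected is a number 0.3 percentage points higher from compound 2 to compound 3 (within the scatter), which means none beyond the scatter. For compound 3 the estimated value is 1.5%, with an expected range from 0.4% to 7%.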

Compound 3, percent of the compound remaining: 1.5%
For compound 3 middle estimate and measured number coincide at the digits printed; the measured number falls inside the stated range.
By their numbers in this assay, from the lowest: compounds 2, 1 and 3 (each within the scatter of the next).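

In this assay, among these compounds, 4-fluorophenyl, which brings fluorine onto this carbonyl carbon for the first time, gave a number 0.3 percentage points higher from compound 2 to compound 3 (within the scatter), and the same group in place of pyridin-4-yl gave a number 0.1 percentage points higher from compound 1 to compound 3 (within the scatter). The series now covers a non-aromatic carbon ring, an aromatic carbon ring bearing fluorine and pyridin-4-yl at this place, and all three compounds stand within the scatter of each other, with very little of each left at the end of the incubation. Nothing at hand explains why the numbers stay together across these groups.

From the compounds shown here alone, whether a group of another kind on this carbonyl carbon, such as an amine, a carboxylic acid or a longer chain, would move the number beyond the scatter remains open. The three compounds share everything outside this one group, so they also leave open which part of the molecule governs how much of the compound is lost, and whether a change to the shared core would leave more of it at the end of the incubation.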